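A few compounds are considered here, and "the series" means these few. Any claim that something is new, unique, unknown or untested is made for them only; others in the source may bear on it.

Of the compounds shown here, three sharing one core have been tested in a functional assay on NCI-H1299 cells (Homo sapiens) for inhibition, read by CCK-8 assay, with a stated time of 72 h, tested at 1 uM; on this read-out lower numbers stand for a weaker effect and higher numbers for a stronger effect at the one concentration tested. Compound 1 `CN(C)C(=O)c1cc2cnc(Nc3ccc(S(=O)(=O)NCCCN=C=S)cc3)nc2n1C1CCCC1` gives 41.3% in this assay. Compound 2 `CN(C)C(=O)c1cc2cnc(Nc3cccc(NC(=O)CCCCCCCN=C=S)c3)nc2n1C1CCCC1` gives 50.6%, a number within the scatter of compound 1, so the two cannot be told apart. Compound 3 `CN(C)C(=O)c1cc2cnc(Nc3ccc(NC(=O)CCCCCCCN=C=S)cc3F)nc2n1C1CCCC1` gives 7.5%, clearly lower than compound 1 and beyond the scatter. Compound 1 thus stands second highest of the three. Compound 4 `CN(C)C(=O)c1cc2cnc(Nc3ccc(N=C=S)cc3)nc2n1C1CCCC1` has not yet been measured; it differs from compound 1 in one place: a group of 3 heavy atoms (1 carbon, 1 nitrogen, 1 sulfur; no ring) in place of a group of 10 heavy atoms (4 carbon, 2 nitrogen, 2 oxygen, 2 sulfur; no ring), on an aromatic carbon. For the measured compounds named here, no measured pair mirrors this change, so the expectation rests on compound 1 alone. The expected step of a number 9.3 percentage points lower from compound 1 to compound 4 (within the scatter) is modest and may not reach beyond the scatter. Compound 4 is therefore estimated at 32%, with a range from 8% to 58%.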

Compound 4, a percentage reported as inhibition, at one concentration (the size of the read-out at that concentration, not a potency): 46.9%
Compound 4: middle estimate off by 14.9 percentage points, on the low side; the measured number falls inside the stated range.
By their numbers in this assay, from the lowest: compound 3; then compounds 1, 4 and 2 (each within the scatter of the next).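

In this assay, putting the group of 3 heavy atoms in place of the group of 10 heavy atoms gives a number 5.6 percentage points higher from compound 1 to compound 4 (within the scatter), so the two cannot be told apart. At this aromatic carbon, then, a much smaller group leaves the read-out unchanged within the scatter, and the sulfonyl-bearing part of compound 1 is not shown to be needed for it. Nothing available explains this result. From the compounds shown here alone, whether an amine, a carboxylic acid or a longer chain at this carbon would shift the number remains open. So does whether these compounds differ in potency, since one concentration gives no potency.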